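This account rests on a few compounds, and the source may have more. Where it says the series, first, only, none or still open, it means among the compounds named here.

Of the compounds shown here, three sharing one core have been read in an ADME assay on BJ cells (Homo sapiens) for cytotoxicity, with a stated time of 72 h; on this read-out higher numbers stand for an effect only at larger amounts of compound and lower numbers for an effect already at smaller amounts. Compound 1 (`Cc1cc(NC(=O)Nc2cccc(N(C)C)c2)c2ccccc2n1`) gives > 25000 nM, and this is a limit of the assay, not a number. Compound 2 (`COc1cccc(NC(=O)Nc2cc(C)nc3ccccc23)c1`) gives 27000 nM. Compound 3 (`Cc1cc(NC(=O)Nc2cccc(OC(F)(F)F)c2)c2ccccc2n1`) gives 25000 nM. For the measured compounds named here, compound 3 therefore shares the readable range with the one other numeric value, and the two cannot be separated: the step is a 1.1-fold lower number from compound 2 to compound 3 (0.03 log units; within the scatter).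

The next compound is compound 4 (`Cc1cc(NC(=O)Nc2cccc(C(C)(C)C)c2)c2ccccc2n1`), with tert-butyl in place of trifluoromethoxy on an aromatic carbon, meta to a large group: tert-butyl in place of trifluoromethoxy on an aromatic carbon. Going by the values given here, no measured step places tert-butyl there, so the evidence is indirect. The exchanges at this aromatic carbon give a step that the limit leaves unreadable from compound 1 to compound 2 and a number no higher from compound 1 to compound 3 (the limit leaves the size open), so neither offers a usable size. Among the compounds with values here, the only sized step, a 1.1-fold lower number from compound 2 to compound 3 (0.03 log units; within the scatter), shows no movement in this assay when the group on the oxygen changes. Within the data shown here, on that basis, no shift beyond the scatter is expected, though with wide uncertainty given the single sized step.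

The estimated step is a 1.1-fold lower number from compound 3 to compound 4 (0.06 log units; within the scatter). For compound 4 the expected value is 22000 nM, with an estimated range of 10000 nM to 40000 nM.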

Compound 4, half-maximal effective concentration: > 25000 nM
Compound 4 was reported as a limit; the forecaster's own chance of this, stated with the estimate: 35%; at least 1.1-fold (0.05 log units) between middle value and limit.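

Tert-butyl in place of trifluoromethoxy on this aromatic carbon gives a number no lower from compound 3 to compound 4 (the limit leaves the size open) in this assay. Compound 4 gives > 25000 nM, which is a limit of the assay and not a number. Tert-butyl is the first group shown at this position with neither oxygen nor nitrogen, and it brings no lower number; the steps from compound 1 and from compound 2 to compound 4 cannot be read, and compound 4 joins compound 1 among the compounds that give no size: the limit of > 25000 nM in this assay, at which 2 of the 4 values shown sit.

It remains open whether any exchange on this aromatic carbon can move the number beyond the scatter, as the only sized step among these compounds, a 1.1-fold lower number from compound 2 to compound 3 (0.03 log units; within the scatter), stays within it. From the compounds shown here alone, what a carboxylic acid or a primary amine at this position would give in this assay also remains open.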